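The source may report more compounds than this note shows. Statements on the series, on what has been measured and on what is new or still open speak of the compounds shown alone.

Measured in a functional assay on brain (Rattus norvegicus, strain Wistar) for inhibition; on this read-out higher numbers stand for weaker inhibition and lower numbers for stronger inhibition:
- compound 1 `CCCCCOc1ccc(-c2c(C)[nH]c(=O)n2C)cc1` gives 4500 nM
- compound 2 `Cc1[nH]c(=O)n(C2CCCCC2)c1-c1ccc(OC(C)C)cc1` gives 13000 nM
- compound 3 `CCCCCOc1ccc(-c2c(C)[nH]c(=O)n2C2CCCCC2)cc1` gives 9100 nM

Compound 3 stands within the scatter of compound 2, so these two cannot be ordered on the numbers shown. Its distance from compound 1 is larger and is set by cyclohexyl in place of methyl on an aromatic nitrogen, which gave a 2.0-fold higher number from compound 1 to compound 3 (0.31 log units; beyond the scatter). That change is not repeated in the next step, where the nitrogen substituent stays cyclohexyl.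

Compound 4 `CCCCCCCCCCCCOc1ccc(-c2c(C)[nH]c(=O)n2C2CCCCC2)cc1` differs only in the chain on the oxygen: heptyl in place of hydrogen on a saturated chain carbon, five bonds along the chain from an oxygen on an aromatic ring. For the measured compounds named here, the one measured change on that oxygen is pentyl in place of isopropyl, which gave a 1.4-fold lower number from compound 2 to compound 3 (0.15 log units; within the scatter) and so stays within the scatter. It is a much smaller change than the one now in view, and no chain of comparable length has been measured, so the series offers only weak guidance on size or direction. No clear step beyond the scatter is therefore expected, with a slight lean towards a lower number. The expected step is a 1.3-fold lower number from compound 3 to compound 4 (0.11 log units; within the scatter), and this estimate is uncertain. The estimated value for compound 4 is 7000 nM, with an expected range from 1800 nM to 28000 nM.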

Compound 4, half-maximal inhibitory concentration: 52400 nM
For compound 4 the middle estimate is 7.5-fold (0.87 log units) below the measured one, and the stated range ends below it.
By their numbers in this assay, from the lowest: compound 1; then compounds 3 and 2 (each within the scatter of the next); then compound 4.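

In this assay, the chain on the oxygen on an aromatic ring now has a step beyond the scatter: heptyl in place of hydrogen on a saturated chain carbon, five bonds along the chain from that oxygen, gave a 5.8-fold higher number from compound 3 to compound 4 (0.76 log units; beyond the scatter) with the cyclohexyl on the nitrogen unchanged. For the compounds shown here, the only earlier change at this oxygen, a 1.4-fold lower number from compound 2 to compound 3 (0.15 log units; within the scatter), stayed within the scatter, so this pair is the first sign that the position does not tolerate every chain length, and the direction here is towards weaker inhibition. Nothing available here explains this loss of inhibition.

The compounds shown leave open whether the number rises gradually with chain length or only past some length, which an octyl or decyl chain on the oxygen would help to settle. Also open, going by these compounds, are whether the same extension has a similar effect with the methyl of compound 1 on the nitrogen, and whether a long chain ending in an amine or a carboxylic acid behaves like the plain chain of compound 4.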